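This account rests on a few compounds, and the source may have more. Where it says the series, first, only, none or still open, it means among the compounds named here.

Measured compounds:
compound 1 `CCOC(=O)c1cc2ccc(OCCCn3cc(CNC(=O)CCCCC4CCSS4)nn3)cc2oc1=O` — 28%
compound 2 `COc1ccc(-c2cc3ccc(OCCCn4cc(CNC(=O)CCCCC5CCSS5)nn4)cc3oc2=O)cc1` — 42%
compound 3 `O=C(CCCCC1CCSS1)NCc1cn(CCCOc2ccc3cc(-c4ccc(Br)cc4)c(=O)oc3c2)nn1` — 39.5%

In a functional assay on PC-12 cells (Rattus norvegicus) for cytotoxicity, read by MTT assay, with stated times of 3 h and 2 h, tested at 0.1 uM (a lower number here means a weaker effect, a higher number a stronger effect of the compound at the concentration tested), compound 1 stands lowest of the three numbers. Compound 4 `O=C(CCCCC1CCSS1)NCc1cn(CCCOc2ccc3cc(-c4ccc(Cl)cc4)c(=O)oc3c2)nn1` differs from compound 1 in one place: 4-chlorophenyl in place of ethoxycarbonyl on an aromatic carbon. Within the data shown here, two measured steps bear on this change. Replacing the ethoxycarbonyl by an aryl group gave a number 14 percentage points higher from compound 1 to compound 2 (beyond the scatter) and a number 11.5 percentage points higher from compound 1 to compound 3 (beyond the scatter), and between the two aryl compounds there was a number 2.5 percentage points lower from compound 2 to compound 3 (within the scatter). The 4-chlorophenyl of compound 4 is nearest in kind to the 4-bromophenyl of compound 3, so a modest step upward, beyond the scatter, is expected in this assay, namely a number 12 percentage points higher from compound 1 to compound 4 (beyond the scatter). Compound 4 is therefore estimated at 40%, with a range from 30% to 50%.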

Compound 4, a percentage reported as activity, at one concentration (the size of the read-out at that concentration, not a potency): 40.9%
Compound 4: middle estimate off by 0.9 percentage points, on the low side; the measured number falls inside the stated range.
By their numbers in this assay, from the lowest: compound 1; then compounds 3, 4 and 2 (each within the scatter of the next).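

In this assay, a third aryl group on this aromatic carbon again stands clear of the ethoxycarbonyl of compound 1, with a number 12.9 percentage points higher from compound 1 to compound 4 (beyond the scatter). Among the aryl compounds, chloro, bromo and methoxy on the phenyl ring are not told apart, with a number 1.4 percentage points higher from compound 3 to compound 4 (within the scatter) and a number 1.1 percentage points lower from compound 2 to compound 4 (within the scatter). Nothing measured here offers an explanation for the step from ethoxycarbonyl to an aryl group. The compounds shown leave open what a carboxylic acid or an aminomethyl group at this position would give, and whether an unsubstituted phenyl would match these aryl compounds.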